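Swapping an ester tail for a sulfo group on a rhodanine chain

The source may hold more compounds than are shown below. What is called first, only, known or untested is meant among the compounds shown, and "the series" means these compounds.

Compound 2 `COC(=O)CCCCCN1C(=O)/C(=C2/C(=O)N(Cc3ccc(C)cc3)c3ccccc32)SC1=S` carries a chain ending in an ester on the ring nitrogen of its shared core. In an assay for inhibition of histone acetyltransferase KAT2B (Homo sapiens), read by TR-FRET, with a stated time of 10 min, tested at 50 uM (a higher number here means more inhibition at the concentration tested (going by the name of the read-out), a lower number less inhibition), compound 2 gives 8%, a low reading that marks little inhibition at the concentration tested. Its closest relative, compound 1 `Cc1ccc(CN2C(=O)/C(=C3\SC(=S)N(CCCCC(=O)O)C3=O)c3ccccc32)cc1`, has a carboxylic acid at the end of the same chain and gives 8%; the step of no change at the digits printed from compound 1 to compound 2 (within the scatter) shows that this change leaves the reading unmoved. Compound 3 `Cc1ccc(CN2C(=O)/C(=C3\SC(=S)N(CCS(=O)(=O)O)C3=O)c3ccccc32)cc1` is the next variation: sulfo in place of 3-(methoxycarbonyl)propyl on a saturated chain carbon, two bonds along the chain from an amide-type nitrogen in a ring. For the measured compounds named here, the only measured step that bears on it is the one from compound 1 to compound 2, which was flat, so a further change in the same tail is expected to move the reading little, if at all, in this assay. Compound 3 is therefore estimated at 8%, with a likely range from -5% to 25%, which means an expected step of no change at the digits printed from compound 2 to compound 3 (within the scatter).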

Compound 3, a percentage reported as inhibition, at one concentration (the size of the read-out at that concentration, not a potency): < 5%
Compound 3 gave a limit, no number; the forecaster's own chance of this, stated with the estimate: 5%; middle value at least 3 percentage points away from the limit.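

The reading for compound 3 is a limit of the assay, not a number: the limit of < 5% in this assay, at which 1 of the 3 values shown sits. Sulfo in place of 3-(methoxycarbonyl)propyl gives a number at least 3 percentage points lower from compound 2 to compound 3 (that floor lies within the scatter), and sulfo in place of 2-carboxyethyl gives a number at least 3 percentage points lower from compound 1 to compound 3 (that floor lies within the scatter). Neither floor goes beyond the scatter, so no loss of inhibition can be claimed, but a third kind of tail on the ring nitrogen, 2-sulfoethyl, brings no rise in this assay.

Compound 3 changes both the end group and the chain length relative to compound 1, so the compounds shown cannot separate the two changes. Going by these compounds, whether any tail here can raise the reading also stays open, for example an amine at the chain end or a longer chain ending in a sulfo group.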